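A few compounds are considered here, and "the series" means these few. Any claim that something is new, unique, unknown or untested is made for them only; others in the source may bear on it.

Measured so far:
- compound 1, `CC(C)=CCC1Cc2c(OCCCNC(=O)c3cccs3)cc(=O)n(CCCO)c2CC1(C)C`, giving 33.6% in a functional assay on PANC-1 cells (Homo sapiens) for inhibition, read by MTT assay, with a stated time of 24 h, tested at 10 uM; a higher number here means more inhibition at the concentration tested (going by the name of the read-out), a lower number less inhibition
- compound 2, `CC(C)=CCC/C(C)=C/COc1cc(=O)n(CCCO)c2c1CC(C/C=C(\C)CCC=C(C)C)C(C)(C)C2`, giving 15.8% in this assay
- compound 3, `CC(C)=CCC/C(C)=C/CC1Cc2c(OCCCNS(=O)(=O)c3ccc(Br)cc3)cc(=O)n(CCCO)c2CC1(C)C`, giving 15.2% in this assay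

Compound 3 gives the lowest of the three numbers in this assay, although its value and that of compound 2 lie within the usual scatter of each other, so no order between those two can be claimed. Compound 1 stands clearly higher, beyond the scatter.

Compound 4, `CC(C)=CCC/C(C)=C/CC1Cc2c(OCCCNC(=O)c3cccs3)cc(=O)n(CCCO)c2CC1(C)C`, has not yet been measured. It differs from compound 3 in one place: (thiophen-2-yl)carbonyl in place of (4-bromophenyl)sulfonyl on an amine nitrogen. The same (thiophen-2-yl)carbonyl group is carried by compound 1, whose value in this assay is the highest shown, but compound 1 also differs from compound 4 elsewhere on the core, so that comparison is only suggestive.

The step in this assay is expected to be small and upward, likely within the scatter: a number 6.8 percentage points higher from compound 3 to compound 4 (within the scatter). Compound 4 is therefore estimated at 22%, with a range from 8% to 38%.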

Compound 4, a percentage reported as inhibition, at one concentration (the size of the read-out at that concentration, not a potency): 72.8%
Compound 4: the middle estimate sits 50.8 percentage points below what was measured; measured number above the stated range.
By their numbers in this assay, from the lowest: compounds 3 and 2 (each within the scatter of the next); then compound 1; then compound 4.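

In this assay the group on this amine nitrogen proves decisive: with the rest of the molecule unchanged, (thiophen-2-yl)carbonyl in place of (4-bromophenyl)sulfonyl gives a number 57.6 percentage points higher from compound 3 to compound 4 (beyond the scatter). That group is not the whole story, since 3-methylbut-2-en-1-yl in place of hydrogen on a saturated chain carbon bound to a double-bonded chain carbon, with the (thiophen-2-yl)carbonyl group present in both compounds, gives a number 39.2 percentage points higher from compound 1 to compound 4 (beyond the scatter). The chain on the oxygen also counts, as 2-(((thiophen-2-yl)carbonyl)amino)ethyl in place of 2,6-dimethylhepta-1,5-dien-1-yl gives a number 57 percentage points higher from compound 2 to compound 4 (beyond the scatter).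

Nothing shown here explains why these changes have such large effects. Going by these compounds, whether the gain follows the thiophene ring or the carbonyl remains open, and a benzoyl group or a thiophene-2-sulfonyl group on the same nitrogen would separate the two.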